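This account rests on a few compounds, and the source may have more. Where it says the series, first, only, none or still open, it means among the compounds named here.

Measured so far:
- Compound 1, `COc1nc(N)nc2c1c(-c1ccsc1)cn2[C@@H]1O[C@H](CO)[C@@H](O)[C@H]1O`: > 20000 nM in a functional assay on K562 cells (Homo sapiens), read by MTT assay, with a stated time of 72 h (a lower number here means a stronger inhibitor, a higher number a weaker inhibitor), a limit of the assay, not a number.
- Compound 2, `COc1nc(N)nc2c1c(-c1cccs1)cn2[C@@H]1O[C@H](CO)[C@@H](O)[C@H]1O`: in this assay compound 2 gives > 20000 nM, again a limit rather than a number.
- Compound 3, `CNc1ncnc2c1c(-c1cccs1)cn2[C@@H]1O[C@H](CO)[C@@H](O)[C@H]1O`: in this assay compound 3 gives > 20000 nM, also a limit.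

Going by the values given here, the only change made twice within the set is thiophen-3-yl in place of thiophen-2-yl on an aromatic carbon. From compound 2 to compound 1 the step is a step that the two limits leave unreadable from compound 2 to compound 1, because both values sit at the limit of > 20000 nM in this assay, at which 3 of the 3 values shown sit. The difference between the core of compound 3 and the core of compound 2 is not broken down here.

Compound 4, `CNc1ncnc2c1c(-c1ccsc1)cn2[C@@H]1O[C@H](CO)[C@@H](O)[C@H]1O`, is not yet measured. It differs from compound 3 by thiophen-3-yl in place of thiophen-2-yl on an aromatic carbon; the place is described in the same words as for the pair of compound 2 and compound 1, so this is the same change. Beside the unreadable step from compound 2 to compound 1, the step from compound 3 to compound 4 is expected to be a step that the limit leaves unreadable from compound 3 to compound 4, resting on compound 3 sitting at the limit of > 20000 nM in this assay, at which 3 of the 3 values shown sit. Compound 4 is therefore expected to give about 30000 nM in this assay, likely reported only as a limit.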

Compound 4, half-maximal inhibitory concentration: > 20000 nM
Compound 4: only a limit was reported (the forecaster's own chance of this, stated with the estimate: 85%); the middle value does not contradict the limit.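

The step from compound 3 to compound 4 cannot be read, and no new step comes from this result, because both compounds sit at the same limit: the limit of > 20000 nM in this assay, at which 4 of the 4 values shown sit.

The compounds shown leave open whether thiophen-3-yl in place of thiophen-2-yl, or the difference between the core of compound 2 and the core of compound 3, changes potency in this assay at all.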